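Aryl substitution in a thiosemicarbazone series: growth inhibition notes

The source may report more compounds than this note shows. Statements on the series, on what has been measured and on what is new or still open speak of the compounds shown alone.

Measured so far in a functional assay on U-251 cells (Homo sapiens) for inhibition, read by sulforhodamine B assay, with a stated time of 48 h; on this read-out higher numbers stand for weaker inhibition of growth and lower numbers for stronger inhibition of growth:
compound 1 `CC1=CC[C@H](C(C)(C)NC(=S)N/N=C/c2ccccc2)CC1`: 26300 nM
compound 2 `CC1=CC[C@H](C(C)(C)NC(=S)N/N=C/c2ccc(O)cc2)CC1`: > 100000 nM, a limit of the assay and not a number

Among the compounds with values here, compound 1 holds the only number in this assay; the other value shown is a limit. Compound 2 differs from it by hydroxy in place of hydrogen on an aromatic carbon and sits at the limit of > 100000 nM in this assay, at which 1 of the 2 values shown sits. Within the data shown here, the single measured step, an at least 3.8-fold higher number from compound 1 to compound 2 (0.58 log units; beyond the scatter), therefore runs toward weaker growth inhibition.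

Compound 3 `CC1=CC[C@H](C(C)(C)NC(=S)N/N=C/c2ccccc2[N+](=O)[O-])CC1` differs from compound 1 by nitro in place of hydrogen on an aromatic carbon. Among the measured compounds shown here, the only step that bears on this is the one to compound 2, and it concerns a different entering group, so it gives direction more than size: the one change tried on this aromatic ring weakened inhibition. For compound 3 the expected step is a 1.5-fold higher number from compound 1 to compound 3 (0.18 log units; within the scatter), a modest rise toward weaker inhibition, with the scatter leaving room for no real change. Compound 3 is thus estimated at 40000 nM, within 15000 nM to 120000 nM, with a real chance that this assay again reports only a limit.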

Compound 3, concentration for 50% growth inhibition: 20200 nM
The estimate for compound 3 lay 2.0-fold (0.30 log units) above the measured number; the measured number falls inside the stated range.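

In this assay the new step is a 1.3-fold lower number from compound 1 to compound 3 (0.11 log units; within the scatter), so nitro on an aromatic carbon, ortho to a large group, leaves growth inhibition indistinguishable from that of compound 1. Substitution on this aromatic ring therefore does not weaken inhibition in every case, and the weakening seen so far rests on a single step with a different group, an at least 3.8-fold higher number from compound 1 to compound 2 (0.58 log units; beyond the scatter). Compound 2 still carries a limit of the assay and not a number: the limit of > 100000 nM in this assay, at which 1 of the 3 values shown sits.

Compound 2 and compound 3 differ from each other in more than one place, so the two steps show only that the outcome on this ring varies with the change made, and they do not separate the entering group from its place on the ring. On these data alone, whether an amine or a carboxylic acid at the position taken by nitro in compound 3 would shift the number beyond the scatter stays open, as does whether any group on this ring can give stronger growth inhibition than compound 1.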